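Methoxyphenyl in Place of Naphthyl: What to Expect

The source may hold more compounds than are shown below. What is called first, only, known or untested is meant among the compounds shown, and "the series" means these compounds.

Compound 2 `c1ccc2c(-c3cn4ccnc4c(-c4ccc5ncn(C6CCCCC6)c5c4)n3)cccc2c1` stands second highest of the three in a functional assay on ACHN cells (Homo sapiens) for inhibition, read by sulforhodamine B assay, with a stated time of 48 h, tested at 10 uM (a lower number here means less inhibition, a higher number more inhibition at the concentration tested (going by the name of the read-out)), with 6.49%; its nearest is compound 3 `CC(=O)c1ccc(-c2cn3ccnc3c(-c3ccc4ncn(C5CCCCC5)c4c3)n2)cc1` at 4.32%, within the scatter, and its furthest is compound 1 `c1ccc(-c2cn3ccnc3c(-c3ccc4ncn(C5CCCCC5)c4c3)n2)cc1` at 35.9%, beyond it. Compound 4 `COc1ccccc1-c1cn2ccnc2c(-c2ccc3ncn(C4CCCCC4)c3c2)n1` differs from compound 2 in one place: 2-methoxyphenyl in place of naphthalen-1-yl on an aromatic carbon. Going by the values given here, two measured steps bear on this. In this assay the step of a number 29.4 percentage points lower from compound 1 to compound 2 (beyond the scatter) and the step of a number 31.6 percentage points lower from compound 1 to compound 3 (beyond the scatter) both show that adding to the phenyl of compound 1 lowered inhibition strongly. Compound 4 carries a substituted phenyl, so it is expected to sit between those cases, giving a number 8.5 percentage points higher from compound 2 to compound 4 (within the scatter). For compound 4 the estimate is 15%, with a range from 0% to 38%.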

Compound 4, a percentage reported as inhibition, at one concentration (the size of the read-out at that concentration, not a potency): 4.48%
Estimate against measurement, compound 4: 10.5 percentage points above; measured number inside the range.
By their numbers in this assay, from the lowest: compounds 3, 4 and 2 (each within the scatter of the next); then compound 1.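

In this assay, the change from compound 2 gives a number 2 percentage points lower from compound 2 to compound 4 (within the scatter), and the change from compound 3 gives a number 0.2 percentage points higher from compound 3 to compound 4 (within the scatter), so 2-methoxyphenyl cannot be told apart from naphthalen-1-yl or 4-acetylphenyl at this position. With a number 31.4 percentage points lower from compound 1 to compound 4 (beyond the scatter), a single methoxy in place of hydrogen proves enough to remove most of the inhibition seen with compound 1, and three different changes to its phenyl now end at one level. Nothing measured here accounts for this. As far as these compounds go, it remains open whether an amine or a carboxylic acid on that phenyl would preserve the inhibition of compound 1, and whether methoxy elsewhere on the ring would match compound 4.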